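From Phenoxy to Dimethylamino: Expected Cytotoxicity of Compound 4

The source may report more compounds than this note shows. Statements on the series, on what has been measured and on what is new or still open speak of the compounds shown alone.

Three compounds were measured in a functional assay on SK-MEL-5 cells (Homo sapiens) for cytotoxicity, read by sulforhodamine B assay, with a stated time of 48 h, tested at 100 nM; on this read-out higher numbers stand for a weaker effect at the one concentration tested and lower numbers for a stronger effect. Compound 1 `COc1cc(C)cc(-c2c(-c3ccnc(-c4ccc(C(C)=O)cc4)c3)cnn2CC#N)c1` gives 85%, compound 2 `COc1cc(C)cc(-c2nn(CC#N)cc2-c2ccc(-c3cccc(C(C)=O)c3)nc2)c1` gives 65%, and compound 3 `Cc1cc(O)cc(-c2nn(CC#N)cc2-c2ccnc(-c3ccc(Oc4ccccc4)cc3)c2)c1` gives 94%. Compound 3 thus stands at the highest of the three numbers; the value of compound 1 lies within the scatter of it, while the value of compound 2 lies beyond the scatter below it. Compound 4 `Cc1cc(O)cc(-c2nn(CC#N)cc2-c2ccnc(-c3ccc(N(C)C)cc3)c2)c1` differs from compound 3 in one place: dimethylamino in place of phenoxy on an aromatic carbon. Among the measured compounds shown here, no pair of measured compounds differs in one place, so nothing measured shows how such a change moves this read-out. Compound 4 is therefore expected to stay close to compound 3, with a step of a number 4 percentage points lower from compound 3 to compound 4 (within the scatter) that lies within the scatter. The estimate for compound 4 in this assay is 90%, in a range from 75% to 102%.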

Compound 4, a percentage reported as activity, at one concentration (the size of the read-out at that concentration, not a potency): 82%
Beside the measured number, compound 4's estimate is 8 percentage points above it, within the range that was stated.
By their numbers in this assay, from the lowest: compound 2; then compounds 4, 1 and 3 (each within the scatter of the next, the first and the last beyond it).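

In this assay, dimethylamino in place of phenoxy, on an aromatic carbon para to a large group, gives the first step measured at this position: a number 12 percentage points lower from compound 3 to compound 4 (beyond the scatter), a modest strengthening of the effect. The position therefore responds to this change, which removes a six-membered aromatic ring of carbon only and keeps the hydrogen-bond acceptor count the same. Nothing at hand explains the step.

The compounds shown leave open whether a primary amine or a carboxylic acid at this place would move the number further. They also leave open whether the same change would give a similar step on another core.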